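Methyl for fluoro at the cytotoxicity limit

The source may hold more compounds than are shown below. What is called first, only, known or untested is meant among the compounds shown, and "the series" means these compounds.

compound 1 `CC(C)(Oc1ccc(Cl)cc1)C(=O)NCCOC(=S)Nc1ccc(F)cc1`: > 800000 nM
compound 2 `O=C(NCCOC(=S)Nc1ccc(F)cc1)c1cccnc1`: > 800000 nM

In an ADME assay on H9c2 cells (Rattus norvegicus) for cytotoxicity, read by MTT assay, with a stated time of 48 h (a higher number here means a weaker inhibitor, a lower number a stronger inhibitor), compound 1 gives > 800000 nM as a limit of the assay and not as a number. Compound 2 gives > 800000 nM as a limit too. Both measured compounds therefore stand at the limit of > 800000 nM in this assay, at which 2 of the 2 values shown sit, and neither has an exact value.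

Compound 3 `Cc1ccc(NC(=S)OCCNC(=O)C(C)(C)Oc2ccc(Cl)cc2)cc1` comes next. It keeps the core of compound 1 but carries methyl in place of fluoro on an aromatic carbon, para to a large group (methyl in place of fluoro on an aromatic carbon), so that 4-fluorophenyl becomes 4-methylphenyl. Going by the values given here, the measured compounds offer no step in this assay that shows what this change does.

No step beyond the usual scatter is expected, in either direction. This expectation rests on compound 1 with its limit of > 800000 nM and on the single replaced atom. The estimated step of a number no higher from compound 1 to compound 3 (the limit leaves the size open) is accordingly expected to be negligible, and a further limit is the likeliest report. Compound 3 is estimated at 800000 nM in this assay with an expected range from 400000 nM to 1600000 nM for a numerical result.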

Compound 3, half-maximal inhibitory concentration: 771000 nM
The estimate for compound 3 lay 1.0-fold (0.02 log units) above the measured number; low and high end bracket the measured number.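

In this assay compound 3 gives 771000 nM, the first exact number among the compounds shown. Read as an at least 1.0-fold lower number from compound 1 to compound 3 (0.01 log units; that floor lies within the scatter), the change from 4-fluorophenyl to 4-methylphenyl on this aromatic carbon is not shown to do anything beyond the scatter, although the step gives only a floor. Most readings in the series still sit at the same limit: the limit of > 800000 nM in this assay, at which 2 of the 3 values shown sit.

As far as these compounds go, compound 1 holds > 800000 nM, a limit and not a number, so the true size of the step remains open. Also open, from the compounds shown here alone, are how an amine, a carboxylic acid or a longer chain on the same aromatic carbon would read in this assay, and whether methyl in place of fluoro would read the same way on the core of compound 2.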